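Extending the Butyl Chain of Compound 3

A few compounds are considered here, and "the series" means these few. Any claim that something is new, unique, unknown or untested is made for them only; others in the source may bear on it.

Measured in a functional assay on HCT-116 cells (Homo sapiens) for antiproliferative activity, read by WST assay, with a stated time of 72 h; a lower number here means that less compound is needed, a higher number that more compound is needed for the effect:
Compound 1 `CCCCNCCCCC(=O)Nc1ccc(/C(N)=N/O)cc1`: 516000 nM
Compound 2 `CCCCNCCCC(=O)Nc1ccc(/C(N)=N/O)cc1`: 267000 nM
Compound 3 `CCCCNCCC(=O)Nc1ccc(/C(N)=N/O)cc1`: 153000 nM

Compound 3 stands at the low end of these numbers. The series shows a 3.4-fold lower number from compound 1 to compound 3 (0.53 log units; beyond the scatter), as well as a 1.7-fold lower number from compound 2 to compound 3 (0.24 log units; within the scatter) and a 1.9-fold lower number from compound 1 to compound 2 (0.29 log units; within the scatter). Compound 4 `CCCCCCNCCC(=O)Nc1ccc(/C(N)=N/O)cc1` carries a different change: ethyl in place of hydrogen on a saturated chain carbon, four bonds along the chain from an amine nitrogen. All three measured steps keep the butylamino group and alter the chain leading to the carbonyl carbon, so none of them makes this change. For the measured compounds named here, they bear on it only indirectly, and the data hold no step for it. No step beyond the scatter is therefore expected in this assay. The expected step is a 1.0-fold lower number from compound 3 to compound 4 (0.01 log units; within the scatter). Compound 4 is expected at 150000 nM, with an estimated range of 60000 nM to 400000 nM.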

Compound 4, half-maximal effective concentration: 193000 nM
For compound 4 the middle estimate is 1.3-fold (0.11 log units) below the measured one, and the stated range covers the measured number.
By their numbers in this assay, from the lowest: compounds 3, 4, 2 and 1 (each within the scatter of the next, the first and the last beyond it).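

In this assay, ethyl in place of hydrogen on a saturated chain carbon, four bonds along the chain from an amine nitrogen, gives a 1.3-fold higher number from compound 3 to compound 4 (0.10 log units; within the scatter), so at this position the change stays within the scatter. Against the compounds with longer chains before the carbonyl carbon, a 1.4-fold lower number from compound 2 to compound 4 (0.14 log units; within the scatter) also stays within the scatter, while a 2.7-fold lower number from compound 1 to compound 4 (0.43 log units; beyond the scatter) lies beyond it, as a modest step. No data given here explain these results.

The compounds shown leave open whether a longer chain, a branched chain or a phenyl group in place of the ethyl would give a step beyond the scatter.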